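Para tert-butyl on the outer phenoxy of a serine phosphodiester

This account rests on a few compounds, and the source may have more. Where it says the series, first, only, none or still open, it means among the compounds named here.

Compound 1, `N[C@@H](COP(=O)(O)OCCCOC(=O)CCc1ccccc1OCc1cccc(Oc2ccccc2)c1)C(=O)O`, gives 21.7% in an assay on HEK293 cells for agonist activity at probable G-protein coupled receptor 34 (Homo sapiens), with a stated time of 1 h; a higher number here means a larger maximal response, a lower number a smaller maximal response.
Compound 2, `Cc1ccccc1Oc1cccc(COc2ccccc2CCC(=O)OCCCOP(=O)(O)OC[C@H](N)C(=O)O)c1`, gives 22% in this assay.
Compound 3, `Cc1ccc(Oc2cccc(COc3ccccc3CCC(=O)OCCCOP(=O)(O)OC[C@H](N)C(=O)O)c2)cc1`, gives 22.1% in this assay.

The three measured compounds share one core and differ only in the outer phenoxy ring. Compound 1 carries the plain ring and its number is the lowest of the three, but the gap to either neighbour lies within the scatter, so the three cannot be told apart. The step of a number 0.3 percentage points higher from compound 1 to compound 2 (within the scatter) and the step of a number 0.4 percentage points higher from compound 1 to compound 3 (within the scatter) both put a methyl onto an aromatic carbon without any change beyond the scatter, and the step of a number 0.1 percentage points higher from compound 2 to compound 3 (within the scatter), which moves that methyl, is likewise flat.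

Compound 4, `CC(C)(C)c1ccc(Oc2cccc(COc3ccccc3CCC(=O)OCCCOP(=O)(O)OC[C@H](N)C(=O)O)c2)cc1`, takes the same route one size further: tert-butyl in place of hydrogen on an aromatic carbon. Both methyl steps bear on this change and both were flat, so compound 4 is expected to sit in the same narrow band, with a step of a number 0.8 percentage points higher from compound 1 to compound 4 (within the scatter) that is expected to stay within the scatter. Compound 4 is estimated at 22.5%, with a range from 14% to 31%.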

Compound 4, largest response reached (Emax), in percent of the reference or control that the assay uses: 28.2%
Estimate against measurement, compound 4: 5.7 percentage points below; the range from low to high includes it.
By their numbers in this assay, from the lowest: compounds 1, 2, 3 and 4 (each within the scatter of the next).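

In this assay, a tert-butyl group with its 4 heavy atoms on this aromatic carbon still leaves the response within the scatter, with a number 6.5 percentage points higher from compound 1 to compound 4 (within the scatter). The same holds against the two methyl compounds, with a number 6.1 percentage points higher from compound 3 to compound 4 (within the scatter) and a number 6.2 percentage points higher from compound 2 to compound 4 (within the scatter), so these steps are larger than the methyl steps, yet none of the four compounds can be told apart from the others. Nothing available here offers an explanation for the size of these steps.

On these data alone, it remains open whether any group on this carbon can move the response beyond the scatter, for instance an amine or a carboxylic acid in place of the tert-butyl. As far as these compounds go, it is also open whether a longer chain would do so.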